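The source may report more compounds than this note shows. Statements on the series, on what has been measured and on what is new or still open speak of the compounds shown alone.

The three measured compounds share one core and differ only in the group on a carbonyl carbon. Compound 1 `COc1ccc2c(c1)OC(c1cc(OC)c(OC)c(OC)c1)C(C(C)=O)=C2` carries a methyl there, and in a functional assay for inhibition of nuclear factor NF-kappa-B complex (Homo sapiens) (on this read-out higher numbers stand for weaker inhibition and lower numbers for stronger inhibition), compound 1 gives 14100 nM. Compound 2 `COc1ccc2c(c1)OC(c1cc(OC)c(OC)c(OC)c1)C(C(=O)OC(C)(C)C)=C2` carries a tert-butoxy in that place, and in this assay compound 2 gives 14100 nM, so that no change at the digits printed from compound 1 to compound 2 (within the scatter). Compound 3 `COc1ccc2c(c1)OC(c1cc(OC)c(OC)c(OC)c1)C(C(=O)O)=C2` carries a hydroxy on the same carbonyl carbon. In this assay compound 3 reaches only a limit of the measurement, > 50000 nM. Compound 3 thus stands as the weakest of the three on the numbers shown, with an at least 3.5-fold higher number from compound 1 to compound 3 (0.54 log units; beyond the scatter) and an at least 3.5-fold higher number from compound 2 to compound 3 (0.54 log units; beyond the scatter); because of the limit of > 50000 nM in this assay, at which 1 of the 3 values shown sits, the true size of its gap is not known.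

Compound 4 `CCNC(=O)C1=Cc2ccc(OC)cc2OC1c1cc(OC)c(OC)c(OC)c1` differs from compound 3 in one place: ethylamino in place of hydroxy on a carbonyl carbon. Among the compounds with values here, the steps that bear on this change are the two that bring the hydroxy in, each raising the number beyond the scatter; compound 4 removes that hydroxy again, as compound 1 and compound 2 lack it. The account therefore expects a lower number for compound 4 in this assay, with an at least 3.3-fold lower number from compound 3 to compound 4 (0.52 log units; beyond the scatter). Compound 4 is estimated at 15000 nM, between 5000 nM and 50000 nM.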

Compound 4, half-maximal inhibitory concentration: > 50000 nM
Compound 4: no number, only a limit; the forecaster's own chance of this, stated with the estimate: 35%; at least 3.3-fold (0.52 log units) between middle value and limit.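

In this assay compound 4 reaches only a limit of the measurement, > 50000 nM. On this carbonyl carbon, ethylamino gives an at least 3.5-fold higher number from compound 1 to compound 4 (0.54 log units; beyond the scatter) when it stands in place of methyl, and an at least 3.5-fold higher number from compound 2 to compound 4 (0.54 log units; beyond the scatter) when it stands in place of tert-butoxy. The earlier compounds shown here tied the higher number to the hydroxy alone, whereas this result shows that taking the hydroxy away does not by itself bring the read-out back to the level of the methyl and tert-butoxy compounds, and that the two groups with equal values in this place do not speak for every replacement of the hydroxy.

From the compounds shown here alone, the order of the two compounds at the limit stays open, and the step between compound 3 and compound 4 cannot be read: the limit of > 50000 nM in this assay, at which 2 of the 4 values shown sit. Also open is whether dimethylamino, methoxy or a chain longer than methyl on this carbonyl carbon would read like compound 1 and compound 2 or would join compound 3 and compound 4 at the limit.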